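A few compounds are considered here, and "the series" means these few. Any claim that something is new, unique, unknown or untested is made for them only; others in the source may bear on it.

Compound 1 `COc1cc(NC(C)CCCNC(=O)NCCCCCO)c2ncccc2c1`: 61000 nM
Compound 2 `COc1cc(NC(C)CCCNC(=O)NCCNC(=O)NCCCC(C)Nc2cc(OC)cc3cccnc23)c2ncccc2c1`: 10000 nM

In a functional assay on MOLT-4 cells (Homo sapiens) (a higher number here means a weaker inhibitor, a lower number a stronger inhibitor), compound 1 has the higher number of the two measured compounds, and the gap down to compound 2 lies beyond the usual scatter. Compound 3 `COC(=O)NCCCC(C)Nc1cc(OC)cc2cccnc12` has not yet been measured. It differs from compound 1 by methoxy in place of (5-hydroxypentyl)amino on a carbonyl carbon, with methoxy in place of (5-hydroxypentyl)amino on a carbonyl carbon. Among the compounds with values here, no measured step tests this change, so the expected result in this assay is no shift beyond the scatter, and the estimated step is a 1.2-fold lower number from compound 1 to compound 3 (0.09 log units; within the scatter). For compound 3 the estimated value is 50000 nM, with an expected range of 18000 nM to 140000 nM.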

Compound 3, half-maximal inhibitory concentration: > 100000 nM
Compound 3: only a limit was reported; the forecaster's own chance of this, stated with the estimate: 25%; middle value at least 2.0-fold (0.30 log units) away from the limit.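

For compound 3 the reading in this assay is only a limit, > 100000 nM. Putting methoxy in place of (5-hydroxypentyl)amino on the carbonyl carbon gives an at least 1.6-fold higher number from compound 1 to compound 3 (0.21 log units; that floor lies within the scatter), so this change brings no lower number, but the floor of the step does not establish a loss beyond the scatter. The true size of the step therefore stays unresolved, and the reading at this position rests on a limit: the limit of > 100000 nM in this assay, at which 1 of the 3 values shown sits.

Still open, going by these compounds, is whether the terminal hydroxyl or the pentyl chain itself matters on this carbonyl carbon. A plain pentylamino group, or a terminal amine or carboxylic acid on the same chain, would separate the two.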